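The compounds below may be only part of what the source reports. "The series", "measured", "known", "first", "only" and "open" are said of these compounds alone.

Compound 1 `CCCCCCOc1nccnc1[C@@H]1CN2CCC1CC2`: 33%. Compound 2 `Clc1cncc(C2CN3CCC2CC3)n1`: 8%. Compound 3 `CCCCCCOc1nccnc1[C@@H]1CN2CCC1C2`: 31%.

In a functional assay on A9L-m1 cells with A9 (Mus musculus) as the target (a lower number here means a smaller maximal response, a higher number a larger maximal response), compound 3 gives 31%, the second highest of the three numbers. Compound 1 gives 33%, a number within the scatter of that of compound 3, so the two cannot be told apart. Compound 2 gives 8%, a number beyond the scatter below that of compound 3. Compound 4 `CCCCCCOc1nccnc1[C@H]1CN2CCC1C2` has not yet been measured in this assay. The change from compound 3 to compound 4 is the two compounds have the same atoms and bonds; at least one stereo element is drawn with a configuration in one of them and without one in the other: 1 of 3 stereo elements differ; a stereocentre at a saturated ring carbon is drawn S in compound 3 and R in compound 4. Among the measured compounds shown here, no measured pair shows such a change, so its size cannot be read from the data. The estimated step of a number 9 percentage points lower from compound 3 to compound 4 (within the scatter) is a small drop, possibly within the scatter. Compound 4 is therefore expected to give about 22%, with a range from 5% to 45%.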

Compound 4, largest response reached (reported as maximum), in percent of the reference or control that the assay uses: 40%
Compound 4: the middle estimate sits 18 percentage points below what was measured; the range from low to high includes it.
By their numbers in this assay, from the lowest: compound 2; then compounds 3, 1 and 4 (each within the scatter of the next).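

Among the compounds shown here, the pair gives the first direct reading of a change of configuration at this saturated ring carbon, with the stereocentre going from S to R. In this assay the result is a number 9 percentage points higher from compound 3 to compound 4 (within the scatter), so on this core the swap leaves no change in maximal response that can be told from the scatter. The reading carries one caveat: the fact that one of compounds 3 and 4 is drawn with a defined configuration and the other without, at the place where they differ.

As far as these compounds go, whether the same swap on the core of compound 1 would behave alike stays open. So does the effect of an amine or a longer chain in place of the chain carried by compound 3 and compound 4.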